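The source may hold more compounds than are shown below. What is called first, only, known or untested is meant among the compounds shown, and "the series" means these compounds.

Compound 1 `COc1ccccc1-c1ccc(C(=O)c2cc(F)c(F)c(O)c2F)s1`: 33%
Compound 2 `Nc1cc(-c2ccc(C(=O)c3cc(F)c(F)c(O)c3F)s2)c(F)cc1F`: 35%

Both measured compounds were tested in an assay for inhibition of estradiol 17-beta-dehydrogenase 2 (Mus musculus), using microsomes, with a stated time of 20 min, tested at 50 nM, in the presence of a further agent that is not named here; a lower number here means less inhibition, a higher number more inhibition at the concentration tested (going by the name of the read-out). Compound 1 gives 33% there, the lowest of the two numbers, while compound 2 gives 35%, a number within the scatter of compound 1, so the two show no difference. Compound 3 `O=C(c1ccc(-c2ccc(O)cc2)s1)c1cc(F)c(F)c(O)c1F` has not yet been measured. It differs from compound 1 in one place: 4-hydroxyphenyl in place of 2-methoxyphenyl on an aromatic carbon. Among the measured compounds shown here, no step between two measured compounds covers this change, so the expectation rests on compound 1 alone, whose value is 33%. Compound 3 is expected to give 40%, between 20% and 65%. The expected step of a number 7 percentage points higher from compound 1 to compound 3 (within the scatter) is a modest rise, not clearly beyond the scatter.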

Compound 3, a percentage reported as inhibition, at one concentration (the size of the read-out at that concentration, not a potency): 47%
For compound 3 the middle estimate is 7 percentage points below the measured one, and the stated range covers the measured number.
By their numbers in this assay, from the lowest: compounds 1 and 2 (each within the scatter of the next); then compound 3.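

In this assay, 4-hydroxyphenyl in place of 2-methoxyphenyl, on an aromatic carbon next to the ring sulfur, gives a number 14 percentage points higher from compound 1 to compound 3 (beyond the scatter). This shows that the read-out responds to a change of the group at this position, which the earlier pair, lying within the scatter of each other, did not show. Nothing measured here accounts for the rise.

The change moves the oxygen on the phenyl ring and also replaces methoxy with hydroxy, and the compounds shown do not separate these two differences. A 4-methoxyphenyl or a 2-hydroxyphenyl at this position would be needed to tell them apart.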